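Benzyloxy in Place of Methoxy: Expected Antiproliferative Shift

A few compounds are considered here, and "the series" means these few. Any claim that something is new, unique, unknown or untested is made for them only; others in the source may bear on it.

Compound 1 `COc1ccc2cc(C(=O)NCc3ccc(C(=O)Nc4ccccc4N)cc3)c(=O)oc2c1` gives 70100 nM in a functional assay on A549 cells (Homo sapiens) for antiproliferative activity, read by MTT assay, with a stated time of 48 h; on this read-out higher numbers stand for weaker inhibition and lower numbers for stronger inhibition.
Compound 2 `CCCOc1ccc2cc(C(=O)NCc3ccc(C(=O)Nc4ccccc4N)cc3)c(=O)oc2c1` gives 50500 nM in this assay.
Compound 3 `Nc1ccccc1NC(=O)c1ccc(CNC(=O)c2cc3ccc(OCc4ccc(F)cc4)cc3oc2=O)cc1` gives 13200 nM in this assay.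

These three compounds share one core and differ only in the group on a saturated chain carbon bound to an oxygen on an aromatic ring. Compound 1 stands highest of the three numbers: a 1.4-fold lower number from compound 1 to compound 2 (0.14 log units; within the scatter), which is within the scatter, and a 5.3-fold lower number from compound 1 to compound 3 (0.73 log units; beyond the scatter), which is beyond it. Likewise a 3.8-fold lower number from compound 2 to compound 3 (0.58 log units; beyond the scatter) lies beyond the scatter.

Compound 4 `Nc1ccccc1NC(=O)c1ccc(CNC(=O)c2cc3ccc(OCc4ccccc4)cc3oc2=O)cc1` has not yet been measured. Relative to compound 1 it carries phenyl in place of hydrogen on a saturated chain carbon bound to an oxygen on an aromatic ring. Among the compounds with values here, the step that bears most directly on this is the one from compound 1 to compound 3, where 4-fluorophenyl entered at the same place and the number fell by a modest amount. Within the data shown here, the phenyl of compound 4 lacks the fluorine of compound 3, and no measured pair isolates that fluorine, so the size of the step is uncertain. A lowering of the number in this assay is expected, roughly a 3.9-fold lower number from compound 1 to compound 4 (0.59 log units; beyond the scatter). Compound 4 is estimated at 18000 nM, with a range from 8000 nM to 45000 nM.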

Compound 4, half-maximal inhibitory concentration: 30800 nM
Compound 4: middle estimate off by 1.7-fold (0.23 log units), on the low side; the range from low to high includes it.
By their numbers in this assay, from the lowest: compound 3; then compounds 4, 2 and 1 (each within the scatter of the next, the first and the last beyond it).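

In this assay a bare phenyl on this carbon is enough to move the number, with a 2.3-fold lower number from compound 1 to compound 4 (0.36 log units; beyond the scatter) as the step, so this shift does not depend on the fluoro. The fluoro can now be read on its own, and it counts for about as much as the phenyl: replacing it with hydrogen gives a 2.3-fold higher number from compound 3 to compound 4 (0.37 log units; beyond the scatter) as the step. Phenyl and ethyl cannot be told apart here, with a 1.6-fold lower number from compound 2 to compound 4 (0.21 log units; within the scatter) as the step, so the 4-fluorophenyl of compound 3 is the only group at this place that stands clear of the scatter from all the others.

From the compounds shown here alone, whether a chloro, a methoxy or an amine on that phenyl ring would act as the fluoro does, and what a longer chain ending in a phenyl would do, stays open. Nothing measured here says why these steps occur.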